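Nitro in place of bromo in a cytotoxicity series

This account rests on a few compounds, and the source may have more. Where it says the series, first, only, none or still open, it means among the compounds named here.

Measured so far:
compound 1, `COc1cc(-c2nnc(SCc3cccc(Br)c3)o2)ccc1O`: 382000 nM
compound 2, `COc1cc(-c2nnc(SCc3ccc(C)cc3)o2)ccc1O`: 549000 nM

In an ADME assay on cells (Mus musculus, strain BALB/c) for cytotoxicity, read by MTT assay, with a stated time of 24 h (a lower number here means that less compound is tolerated, a higher number that more compound is tolerated), compound 1 gives 382000 nM, the lowest of the two numbers shown. For the measured compounds named here, its only neighbour is compound 2, and the single measured step, a 1.4-fold higher number from compound 1 to compound 2 (0.16 log units; within the scatter), lies within the scatter, so the two values cannot be ordered.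

Compound 3, `COc1cc(-c2nnc(SCc3cccc([N+](=O)[O-])c3)o2)ccc1O`, is compound 1 with one change: nitro in place of bromo on an aromatic carbon. Going by the values given here, the one step that bears on this change is the one that also varies the group on the saturated chain carbon bound to a sulfur, and that step was within the scatter. Among the compounds with values here, with only that step to lean on, no shift beyond the scatter is expected for compound 3 in this assay; the expected step is a 1.1-fold higher number from compound 1 to compound 3 (0.04 log units; within the scatter). Compound 3 is therefore estimated at 420000 nM, with a range from 200000 nM to 900000 nM.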

Compound 3, half-maximal cytotoxic concentration: 392000 nM
Compound 3: the middle estimate sits 1.1-fold (0.03 log units) above what was measured; measured number inside the range.
By their numbers in this assay, from the lowest: compounds 1, 3 and 2 (each within the scatter of the next).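

In this assay, nitro in place of bromo on an aromatic carbon, meta to a large group, gives a 1.0-fold higher number from compound 1 to compound 3 (0.01 log units; within the scatter), so compound 1 and compound 3 cannot be told apart even though 3 heavy atoms with 2 hydrogen-bond acceptors replace a single bromine. For the compounds shown here, the only other step, between compound 1 and compound 2, exchanged 3-bromophenyl for 4-methylphenyl and so altered place and group together, whereas here the place is held and only the group differs. Nothing measured here speaks to the reason for this result.

The compounds shown leave open whether an amine or a carboxylic acid on this same aromatic carbon would also stay within the scatter of compound 1. They also leave open whether a longer chain between the sulfur and the ring would do so.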